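The compounds below may be only part of what the source reports. "The series", "measured", "known", "first", "only" and "open" are said of these compounds alone.

Compound 2 `Oc1nncc2cncn12` is the smaller of two measured compounds. In a functional assay for inhibition, with Homo sapiens as the target (on this read-out higher numbers stand for weaker inhibition and lower numbers for stronger inhibition), compound 2 gives > 48000 nM, which is a limit of the measurement and not a number. Compound 1 `Cc1ncn2c(O)nncc12` carries a methyl group on the shared core; in this assay compound 1 gives > 48000 nM, again a limit. Among the measured compounds shown here, the single measured step, a step that the two limits leave unreadable from compound 1 to compound 2, cannot be sized, as the limit of > 48000 nM in this assay, at which 2 of the 2 values shown sit. Compound 3 `CCc1ncn2c(O)nncc12` differs from compound 2 by ethyl in place of hydrogen on an aromatic carbon. With no readable step to build on, no change beyond the scatter is expected, and the value is likely to be a limit once more. Compound 3 is estimated at 100000 nM, within 40000 nM to 300000 nM. The expected step is a step that the limit leaves unreadable from compound 2 to compound 3.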

Compound 3, half-maximal inhibitory concentration: > 48000 nM
Compound 3 ended at the assay's limit; the forecaster's own chance of this, stated with the estimate: 85%; the middle value does not contradict the limit.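

Compound 1, compound 2 and compound 3 all end at a limit of the measurement and not at a number, so no step among them can be read: the limit of > 48000 nM in this assay, at which 3 of the 3 values shown sit.

On these data alone, whether hydrogen, methyl or ethyl on this aromatic carbon changes inhibition at all stays open.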